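Amide nitrogen change from compound 3 to compound 4

A few compounds are considered here, and "the series" means these few. Any claim that something is new, unique, unknown or untested is made for them only; others in the source may bear on it.

Measured in an in vitro ADME assay on microsomes from liver (Mus musculus) for pharmacokinetics, read by LC-MS, with a stated time of 10 min, tested at 1 uM; on this read-out lower numbers stand for slow clearance and higher numbers for fast clearance:
compound 1 `Cc1cc(NC(=O)[C@H]2CN(C)C[C@@H]2c2ccc(/C=C/C(=O)Nc3ccccc3N)cc2)ccc1F` gives 62 mL/min/kg
compound 2 `CN1C[C@H](C(=O)Nc2ccc(F)c(Br)c2)[C@@H](c2ccc(/C=C/C(=O)Nc3ccccc3N)cc2)C1` gives 43 mL/min/kg
compound 3 `Cc1ccc(NC(=O)[C@H]2CN(C)C[C@@H]2c2ccc(/C=C/C(=O)Nc3ccccc3N)cc2)cn1` gives 57 mL/min/kg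

Compound 3 at 57 mL/min/kg is not separated from the other two compounds. Compound 4 `CN1C[C@H](C(=O)NC2CCCC2)[C@@H](c2ccc(/C=C/C(=O)Nc3ccccc3N)cc2)C1` has not yet been measured and differs from compound 3 on the amide-type nitrogen: cyclopentyl in place of 6-methylpyridin-3-yl on an amide-type nitrogen. In words, cyclopentyl stands in place of 6-methylpyridin-3-yl. The closest evidence comes from two changes at that nitrogen, a 1.1-fold lower number from compound 1 to compound 3 (0.04 log units; within the scatter) and a 1.3-fold higher number from compound 2 to compound 3 (0.12 log units; within the scatter). For the measured compounds named here, both involve aromatic groups only, and no measured compound has a non-aromatic ring there, so they guide the expectation only loosely. No step beyond the scatter is expected in this assay, and no direction is favoured. The expected change is a 1.0-fold lower number from compound 3 to compound 4 (0.02 log units; within the scatter). The estimate for compound 4 is 55 mL/min/kg, with an expected range of 30 mL/min/kg to 95 mL/min/kg.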

Compound 4, clearance: 61 mL/min/kg
Compound 4: middle estimate off by 1.1-fold (0.04 log units), on the low side, within the range that was stated.
By their numbers in this assay, from the lowest: compounds 2, 3, 4 and 1 (each within the scatter of the next).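

In this assay, the amide-type nitrogen now carries a non-aromatic ring for the first time among the compounds shown, and cyclopentyl stays within the scatter of all three aromatic groups: a 1.1-fold higher number from compound 3 to compound 4 (0.03 log units; within the scatter), a 1.4-fold higher number from compound 2 to compound 4 (0.15 log units; within the scatter) and a 1.0-fold lower number from compound 1 to compound 4 (0.01 log units; within the scatter). At this position, then, an aromatic ring is not needed to keep the clearance number where it stands, though that number remains fast. No measured evidence accounts for this result. As far as these compounds go, whether an amine, a carboxylic acid or a longer alkyl chain on this nitrogen would give a step beyond the scatter stays open.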